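From 4-chlorophenyl to 3-(trifluoromethyl)phenyl on a shared core

The source may report more compounds than this note shows. Statements on the series, on what has been measured and on what is new or still open speak of the compounds shown alone.

- compound 1 `O=C(CCc1cccc2c1B(O)OC2)Nc1cccc(I)c1`: 2300 nM
- compound 2 `O=C(CCc1cccc2c1B(O)OC2)Nc1cccc(-c2ccc(F)cc2)c1`: 550 nM
- compound 3 `O=C(CCc1cccc2c1B(O)OC2)Nc1cccc(-c2ccc(Cl)cc2)c1`: 380 nM

All three compounds were tested in a functional assay on HCT-116 cells (Homo sapiens) for antiproliferative activity, read by MTT assay, with a stated time of 72 h; a lower number here means a stronger inhibitor, a higher number a weaker inhibitor. Compound 3 stands with compound 2 at the low end of these numbers. The data show a 1.4-fold lower number from compound 2 to compound 3 (0.16 log units; within the scatter), and they also show a 6.1-fold lower number from compound 1 to compound 3 (0.78 log units; beyond the scatter).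

The next change leads to compound 4 `O=C(CCc1cccc2c1B(O)OC2)Nc1cccc(-c2cccc(C(F)(F)F)c2)c1`, which has 3-(trifluoromethyl)phenyl in place of 4-chlorophenyl on an aromatic carbon. For the measured compounds named here, no measured compound carries this group, so the evidence is indirect. The closest guide is the chloro-for-fluoro swap, a 1.4-fold lower number from compound 2 to compound 3 (0.16 log units; within the scatter), which also alters the outer ring. Going by the values given here, the other measured steps, a 4.2-fold lower number from compound 1 to compound 2 (0.62 log units; beyond the scatter) and the one to compound 3 already noted, replace iodo with a substituted phenyl. Compound 4 keeps a substituted phenyl at that place, so a change of that size is not expected here.

In this assay, a step within the scatter is therefore expected, with a slight lean toward a higher number, as the new group has not been tested. The expected step is a 1.3-fold higher number from compound 3 to compound 4 (0.10 log units; within the scatter). For compound 4 the estimated value is 480 nM, with an expected range from 190 nM to 1200 nM.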

Compound 4, half-maximal inhibitory concentration: 580 nM
Beside the measured number, compound 4's estimate is 1.2-fold (0.08 log units) below it, within the range that was stated.
By their numbers in this assay, from the lowest: compounds 3, 2 and 4 (each within the scatter of the next); then compound 1.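

Until now the outer ring had varied only in the halogen on a 4-substituted phenyl, and the new result shows that 3-(trifluoromethyl)phenyl, a different substituent on that ring, also leaves the number in this assay within the scatter of both halogen-bearing rings (a 1.5-fold higher number from compound 3 to compound 4 (0.18 log units; within the scatter)) and (a 1.1-fold higher number from compound 2 to compound 4 (0.02 log units; within the scatter)). The separation from the iodo compound also holds for this third substituted phenyl (a 4.0-fold lower number from compound 1 to compound 4 (0.60 log units; beyond the scatter)), so among the compounds shown, all three with a substituted phenyl at this place lie apart from compound 1, and none goes against this. Nothing available here bears on why these substituted phenyl groups give such similar numbers.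

The compounds shown leave open whether 3-chlorophenyl or 4-(trifluoromethyl)phenyl would stay in the same band, which would help separate the identity of the substituent from its place on the outer ring. For the compounds shown here, they also leave open what an outer ring carrying an amine or a carboxylic acid would do, or what a longer chain in place of the outer ring would do, since every group at this place so far, apart from iodo, is a phenyl bearing a halogen or trifluoromethyl.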